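This account rests on a few compounds, and the source may have more. Where it says the series, first, only, none or still open, it means among the compounds named here.

Two compounds built on one shared core were examined in a functional assay on MDA-MB-231 cells (Homo sapiens) for cytotoxicity, read by MTT assay, with a stated time of 24 h; on this read-out lower numbers stand for stronger inhibition and higher numbers for weaker inhibition. Compound 1 `Cc1cc(O)c(C(=O)/C=C/c2ccc(F)cc2)c(-c2ccccc2)c1C(=O)/C=C/c1ccc(F)cc1` gave 20000 nM in this assay. Compound 2 `Cc1cc(O)c(C(=O)/C=C/c2cccc3ccccc23)c(-c2ccccc2)c1C(=O)/C=C/c1cccc2ccccc12` was reported as "not active" (no number reported) in this assay, and no number accompanies that report, so compound 2 stands with no single value on the scale at all. The step to compound 3 `Cc1cc(O)c(C(=O)/C=C/c2cccc3ccccc23)c(-c2ccc(Cl)cc2)c1C(=O)/C=C/c1cccc2ccccc12` carries one change, (chloro in place of hydrogen on an aromatic carbon). Within the data shown here, no measured pair in this set differs in that one place, so there is no measured step to lean on. Compound 2 gave no number in this assay, and compound 1 sits at 20000 nM. On that footing the addition is expected to move the read-out little, if at all, beyond the scatter in either direction, with the likeliest outcome again a report without a number. Compound 3 is therefore estimated at 40000 nM in this assay, expected to fall between 12000 nM and 120000 nM.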

Compound 3, half-maximal inhibitory concentration: 30000 nM
Compound 3: middle estimate off by 1.3-fold (0.12 log units), on the high side; the range from low to high includes it.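

The step from compound 2 to compound 3 cannot be read: compound 2 has no number in this assay, while compound 3 gives 30000 nM on the same scale. Going by these compounds, what the change from phenyl to 4-chlorophenyl does to this read-out stays open. No outside evidence bears on this result.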